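Loss of an aromatic methyl across two cores

The source may hold more compounds than are shown below. What is called first, only, known or untested is meant among the compounds shown, and "the series" means these compounds.

Measured so far, in a functional assay on L1210 cells (Mus musculus) for antiproliferative activity; on this read-out lower numbers stand for stronger inhibition and higher numbers for weaker inhibition:
compound 1 `Cc1nsc2[nH]c(SCc3ccccc3)nc12`: 7000 nM
compound 2 `c1ccc(CSc2nc3cnsc3[nH]2)cc1`: 300 nM
compound 3 `CSc1nc2c(C)nsc2n1[C@H]1C[C@H](O)[C@@H](CO)O1`: > 100000 nM

Compound 1 and compound 2 share a core and differ in one place, (hydrogen in place of methyl on an aromatic carbon). That step gives a 23-fold lower number from compound 1 to compound 2 (1.37 log units; beyond the scatter). The value of compound 3 in this assay is a limit of the assay and not a number; it is the limit recorded as the limit of > 100000 nM in this assay, at which 1 of the 3 values shown sits. The difference between the core of compound 3 and the core of compound 1 is not broken down here.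

Compound 4 `CSc1nc2cnsc2n1[C@H]1C[C@H](O)[C@@H](CO)O1` is not yet measured. It is related to compound 3 by hydrogen in place of methyl on an aromatic carbon, and the change sits in the same surroundings as the change from compound 1 to compound 2, so it is the same change made on a second core. Among the measured compounds shown here, whether the step repeats on this core cannot be read from one pair; the only guidance is that the earlier step was large and beyond the scatter.

Compound 4 is therefore expected to give a lower number than compound 3, with the step estimated as an at least 5.0-fold lower number from compound 3 to compound 4 (0.69 log units; beyond the scatter) in this assay. The expectation for compound 4 is wide, estimated at 20000 nM with a range from 3000 nM to 150000 nM, and a fair chance remains that the assay again returns only a limit.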

Compound 4, half-maximal inhibitory concentration: > 100000 nM
Compound 4: no number, only a limit; the forecaster's own chance of this, stated with the estimate: 40%; middle value at least 5.0-fold (0.69 log units) away from the limit.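

In this assay, among the compounds shown here, compound 3 and compound 4 both return only a limit and not a number, so no step between them can be read: the limit of > 100000 nM in this assay, at which 2 of the 4 values shown sit. The compounds shown leave open whether hydrogen in place of methyl on an aromatic carbon does anything on the core of compound 3 comparable to a 23-fold lower number from compound 1 to compound 2 (1.37 log units; beyond the scatter) on the core of compound 1.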